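This account rests on a few compounds, and the source may have more. Where it says the series, first, only, none or still open, it means among the compounds named here.

Measured so far:
- compound 1, `COc1ccccc1N1CCN(CCCOc2ccccc2C(=O)N(C)C)CC1`: 31.6 nM
- compound 2, `CN(C)C(=O)c1cccnc1NCCCN1CCN(c2ccccc2)CC1`: 15.9 nM

Both numbers come from a functional assay on aorta for antagonist activity at Alpha-1D adrenergic receptor (Rattus norvegicus); on this read-out higher numbers stand for weaker binding and lower numbers for tighter binding. In this assay compound 1 gives 31.6 nM and compound 2 gives 15.9 nM. The two values lie within the usual scatter of each other, so compound 2 is not set apart from compound 1 on these numbers; the two compounds also differ in more than one place, so no single step can be read from the pair.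

The new compound is compound 3, `CSc1ccccc1N1CCN(CCCNc2ncccc2C(=O)N(C)C)CC1`. Compared with compound 2, it carries methylsulfanyl in place of hydrogen on an aromatic carbon. Nothing measured here shows what a methylsulfanyl group in this place does, so the expectation rests on the general closeness of compound 1 and compound 2 rather than on a recorded step. For compound 3 a step of a 1.6-fold lower number from compound 2 to compound 3 (0.20 log units; within the scatter) in this assay is expected, that is, a small gain that may still fall within the scatter. Compound 3 is therefore estimated at 10 nM, with a range from 3 nM to 40 nM.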

Compound 3, dissociation constant: 31.6 nM
Estimate against measurement, compound 3: 3.2-fold (0.50 log units) below; the range from low to high includes it.
By their numbers in this assay, from the lowest: compounds 2, 1 and 3 (each within the scatter of the next).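

In this assay, compound 2 and compound 3 are the only pair shown that differs in a single place, phenyl to 2-(methylsulfanyl)phenyl, so this is the one change that can be read directly, and it amounts to a 2.0-fold higher number from compound 2 to compound 3 (0.30 log units; within the scatter). This shows that placing methylsulfanyl, with its 2 heavy atoms, on an aromatic carbon ortho to a large group does not separate the two compounds on this read-out, even though the new group is much larger than the hydrogen it replaces. No measurement shown here offers an explanation for this result.

This single pair covers only one replacement at one position, so it cannot show how far the tolerance for change at this position extends. Going by these compounds, whether a carboxylic acid, an amine or a longer chain such as ethylsulfanyl at the same place would stay within the scatter of compound 2 or move clearly away from it remains open.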